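The source may hold more compounds than are shown below. What is called first, only, known or untested is meant among the compounds shown, and "the series" means these compounds.

Measured so far:
compound 1 `COc1ncc(-c2ccc(C(=O)O)cc2C)cc1-c1ncc(C(F)(F)F)cc1[C@@H]1CC[C@H]2[C@@H](c3cc(C(F)(F)F)cc(C(F)(F)F)c3)OC(=O)N12` in an ADME assay on isolated protein for inhibition of solute carrier organic anion transporter family member 1B1 (Homo sapiens) (on this read-out higher numbers stand for weaker inhibition and lower numbers for stronger inhibition), gives < 1000 nM, a limit only.
compound 2 `COc1ccc(-c2c(C)cc(C(=O)O)cc2C)cc1-c1ccc(C(F)(F)F)cc1[C@@H]1CC[C@H]2[C@@H](c3cc(C(F)(F)F)cc(C(F)(F)F)c3)OC(=O)N12` in this assay gives < 1000 nM, again a limit only.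

Compound 2 therefore stands at the limit of < 1000 nM in this assay, at which 2 of the 2 values shown sit, and cannot be ranked against compound 1; both merely lie at the limit. Compound 3 `COc1ccc(CCC(=O)O)cc1-c1ccc(C(F)(F)F)cc1[C@@H]1CC[C@H]2[C@@H](c3cc(C(F)(F)F)cc(C(F)(F)F)c3)OC(=O)N12` remains to be measured; it differs from compound 2 by 2-carboxyethyl in place of 4-carboxy-2,6-dimethylphenyl on an aromatic carbon. Among the compounds with values here, no measured pair carries this change, so the step is expected as a loss of inhibition of moderate size, an at least 1.5-fold higher number from compound 2 to compound 3 (0.17 log units; that floor lies within the scatter). Compound 3 is estimated at 1500 nM, within 400 nM to 6000 nM.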

Compound 3, half-maximal inhibitory concentration: 2000 nM
Beside the measured number, compound 3's estimate is 1.3-fold (0.12 log units) below it; low and high end bracket the measured number.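

In this assay, within the data shown here, 2-carboxyethyl in place of 4-carboxy-2,6-dimethylphenyl, para to a methoxy group, gives the first readable step at this position: an at least 2.0-fold higher number from compound 2 to compound 3 (0.30 log units; that floor lies within the scatter). The floor lies within the scatter, but this simpler group without a ring gives an actual number rather than a limit. Compound 2 holds only a limit, so the full size of the step stays unknown: the limit of < 1000 nM in this assay, at which 2 of the 3 values shown sit.

Still open, on these data alone, is how a longer chain ending in the same acid, or a primary amide in its place, would read, and how far compound 1 and compound 2 lie past their limits.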